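A few compounds are considered here, and "the series" means these few. Any claim that something is new, unique, unknown or untested is made for them only; others in the source may bear on it.

Measured compounds:
- Compound 1, `O=C(O)Cc1sc(Cc2ccccc2)nc1-c1ccc(Cl)cc1`, gives > 70% in an in vitro functional assay on HEK285-7 cells for antagonist activity at prostaglandin D2 receptor 2 (Homo sapiens), read by BRET and beta-arrestin recruitment; on this read-out higher numbers stand for larger maximal responses and lower numbers for smaller maximal responses
- Compound 2, `O=C(O)Cc1sc(Cc2ccc(Cl)cc2)nc1-c1ccccc1`, gives > 70% in this assay

Both of these values are limits of this assay rather than exact numbers. For compound 1 the reported value is such a limit. For compound 2 the value is likewise only a limit, and compound 2 therefore stands at the limit of > 70% in this assay, at which 2 of the 2 values shown sit. Where compound 2 lies above that mark is not known.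

Compound 3, `O=C(O)Cc1sc(Cc2ccc(Cl)cc2)nc1-c1ccc(Cl)cc1`, is not yet measured. It differs from compound 2 in a single place: chloro in place of hydrogen on an aromatic carbon. The chlorine enters on an aromatic carbon of a six-membered aromatic ring of carbon only, para to a large group.

Among the compounds with values here, no step between two measured compounds is available, so the size of the change from compound 2 to compound 3 cannot be read off from data. Since compound 1 and compound 2 each carry one chloro on either ring and both reach the limit, a step that the limit leaves unreadable from compound 2 to compound 3 is expected in this assay, none beyond the scatter. Compound 3 is therefore expected to give 85%, with a range from 65% to 100%, most likely reported again only as a limit.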

Compound 3, largest response reached (reported as efficacy), in percent of the reference or control that the assay uses: > 70%
Compound 3: a limit, no number; the forecaster's own chance of this, stated with the estimate: 80%; the middle value is on the limit's open side.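

In this assay compound 3 gives > 70%, which is a limit and not a number. Compound 1 and compound 2 also carry only limits, so no step from either of them to compound 3 can be read: the limit of > 70% in this assay, at which 3 of the 3 values shown sit.

On these data alone, what stays open is how far each of the three compounds lies past that limit, and so whether adding a chloro changes the maximal response at all.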